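The compounds below may be only part of what the source reports. "The series", "measured", "known", "first", "only" and "open" are said of these compounds alone.

Compound 1 `Nc1scc(CN2CCN(c3ccc(Cl)cc3F)CC2)c1C(=O)c1ccc(Cl)cc1` gives 1% in an assay on CHO cells for displacement of a labelled ligand from adenosine receptor A3 (Homo sapiens), read by scintillation counting, with a stated time of 120 min, tested at 10 uM; a lower number here means less inhibition, a higher number more inhibition at the concentration tested (going by the name of the read-out). Compound 2 `Nc1scc(CN2CCN(c3cccnc3)CC2)c1C(=O)c1ccc(Cl)cc1` gives 0% in this assay.

Of the two numbers shown, compound 2 stands lowest, with compound 1 nearest to it; the step of a number 1 percentage points lower from compound 1 to compound 2 (within the scatter) lies within the scatter, so the two values cannot be told apart. Both compounds show essentially no displacement at the concentration tested.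

Compound 3 `Nc1scc(CN2CCN(C3CCCC3)CC2)c1C(=O)c1ccc(Cl)cc1` differs from compound 2 by cyclopentyl in place of pyridin-3-yl on an amine nitrogen in a ring. Among the compounds with values here, the only measured step that bears on this position is the one from compound 1 to compound 2, where one group on that ring nitrogen was exchanged for another and the read-out did not move beyond the scatter. With both measured compounds near the bottom of the scale, a step of a number 3 percentage points higher from compound 2 to compound 3 (within the scatter) is expected, that is none beyond the scatter. Compound 3 is therefore estimated at 3% in this assay, within a range from 0% to 15%.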

Compound 3, a percentage reported as inhibition, at one concentration (the size of the read-out at that concentration, not a potency): 3%
For compound 3 middle estimate and measured number coincide at the digits printed; measured number inside the range.
By their numbers in this assay, from the lowest: compounds 2, 1 and 3 (each within the scatter of the next).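

Within the data shown here, on the amine nitrogen in the ring, cyclopentyl, a non-aromatic ring of carbon only, replaces the aromatic rings of the earlier compounds, and in this assay this gives a number 3 percentage points higher from compound 2 to compound 3 (within the scatter) and a number 2 percentage points higher from compound 1 to compound 3 (within the scatter). Across these three compounds, the read-out therefore does not separate an aromatic group from a non-aromatic one at this position, nor pyridin-3-yl, with its hydrogen-bond acceptor, from cyclopentyl, which has none. No evidence is at hand on why the values stay at the bottom of the scale.

As far as these compounds go, whether any group on this nitrogen can raise the read-out beyond the scatter stays open, for instance a benzyl group, an open alkyl chain or an acetyl group. Also open, from the compounds shown here alone, is whether a change elsewhere on the shared core would do so.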